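Methyl to benzyl on the ring-bound amine of the shared core

A few compounds are considered here, and "the series" means these few. Any claim that something is new, unique, unknown or untested is made for them only; others in the source may bear on it.

Measured compounds:
compound 1 `CN(Cc1cccc(B(O)O)c1)c1ccc(C(=O)Nc2ccc(F)cc2)cn1` gives 4100 nM in a functional assay on RBL cells for antagonist activity at C-X-C chemokine receptor type 1 (Homo sapiens), read by fluorescence and calcium flux, with a stated time of 30 min; on this read-out lower numbers stand for stronger inhibition and higher numbers for weaker inhibition
compound 2 `CN(Cc1ccc(B(O)O)cc1)c1ccc(C(=O)Nc2ccc(F)cc2)cn1` gives 1400 nM in this assay
compound 3 `CN(Cc1ccc(B(O)O)cn1)c1ccc(C(=O)Nc2ccc(F)cc2)cn1` gives 1700 nM in this assay

Compound 3 stands second highest of the three numbers. Its nearest neighbour is compound 2, the gap between them lying within the scatter, so no order between compound 2 and compound 3 can be claimed. Compound 1 is furthest off: the step of a 2.4-fold lower number from compound 1 to compound 3 (0.38 log units; beyond the scatter) is modest but beyond the scatter, as is a 2.9-fold lower number from compound 1 to compound 2 (0.47 log units; beyond the scatter).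

Compound 4 `O=C(Nc1ccc(F)cc1)c1ccc(N(Cc2ccccc2)Cc2ccc(B(O)O)cn2)nc1` has not been measured. It differs from compound 3 by phenyl in place of hydrogen on a saturated chain carbon bound to a nitrogen on an aromatic ring. All three measured steps exchange the boronic-acid-bearing ring on the chain carbon, leaving the methyl on the amine untouched; none of them varies the group that changes here. For the measured compounds named here, no measured step therefore bears on this exchange, and the expectation rests only on the value of compound 3 itself.

With nothing in the series pointing either way, the step of a 1.1-fold higher number from compound 3 to compound 4 (0.02 log units; within the scatter) is expected to stay close to no change, with a wide range to either side. Compound 4 is estimated at 1800 nM, between 500 nM and 6000 nM.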

Compound 4, half-maximal inhibitory concentration: 326 nM
Estimate against measurement, compound 4: 5.5-fold (0.74 log units) above, outside the stated range (below it).
By their numbers in this assay, from the lowest: compound 4; then compounds 2 and 3 (each within the scatter of the next); then compound 1.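

In this assay, for the compounds shown here, methyl to benzyl on the ring-bound amine of the shared core gives a 5.2-fold lower number from compound 3 to compound 4 (0.72 log units; beyond the scatter), the only measured exchange at this place, on a saturated chain carbon bound to a nitrogen on an aromatic ring. The earlier steps shown here varied only the boronic-acid-bearing ring while the methyl stayed fixed, so they could not show whether this place responds at all; it does, and a phenyl with no net charge is accommodated here with a lower number rather than a higher one. Nothing among the data shown explains this step.

As far as these compounds go, whether the lower number needs the aromatic phenyl ring or would also follow from an ethyl, a longer alkyl chain or a cyclohexyl on the chain carbon stays open, as does the outcome of a fluorine, a methoxy or an amine on the new ring. Also open, from the compounds shown here alone, is whether the same exchange would carry over to the boronic-acid-bearing rings of compound 1 and compound 2, as the finding rests on a single pair.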